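The source may report more compounds than this note shows. Statements on the series, on what has been measured and on what is new or still open speak of the compounds shown alone.

The series shares one core, seen in compound 1 `COc1cc2c(cc1OC)C(CC(=O)O)CC2`, which carries hydroxy on the carbonyl carbon. In a functional assay on the whole organism (strain Wistar) for inhibition, with Rattus norvegicus as the target, read by paw edema, with stated times of 60 min and 4 h, at a dose of 100 mg/kg by the oral route (on this read-out higher numbers stand for more inhibition at the one dose given (going by the name of the read-out) and lower numbers for less inhibition), compound 1 gives 23.9%. Compound 2 `COc1cc2c(cc1OC)C(CC(N)=O)CC2` carries amino on that carbonyl carbon; in this assay compound 2 gives 31.3%, the highest of the three numbers, though its distance to compound 3 and to compound 1 lies within the scatter in both cases. Compound 3 `COc1cc2c(cc1OC)C(CC(=O)N1CCCC1)CC2` carries pyrrolidin-1-yl on the carbonyl carbon, and in this assay compound 3 gives 24.2%. The three steps between them, a number 7.4 percentage points higher from compound 1 to compound 2 (within the scatter), a number 0.3 percentage points higher from compound 1 to compound 3 (within the scatter) and a number 7.1 percentage points lower from compound 2 to compound 3 (within the scatter), all stay within the scatter, so the three measured compounds cannot be ordered.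

Compound 4 `COc1cc2c(cc1OC)C(CC(=O)N1CCOCC1)CC2` is not yet measured. morpholin-4-yl in place of amino on a carbonyl carbon The step that bears on it most is the exchange of amino for pyrrolidin-1-yl on the same carbonyl carbon, which stayed within the scatter, and hydroxy in that place sits within the scatter of both. Nothing in the measured steps points to a change beyond the scatter when morpholin-4-yl enters. Compound 4 is therefore expected to give 27% in this assay, with a range from 13% to 41%. The expected step is a number 4.3 percentage points lower from compound 2 to compound 4 (within the scatter), within the scatter.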

Compound 4, a percentage reported as inhibition, in the whole organism at one dose (the size of the read-out at that dose, not a potency): 13.3%
Beside the measured number, compound 4's estimate is 13.7 percentage points above it, within the range that was stated.
By their numbers in this assay, from the lowest: compound 4; then compounds 1, 3 and 2 (each within the scatter of the next).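

On the carbonyl carbon whose other neighbours are a saturated chain carbon, the series now shows a change that leaves the scatter in this assay: the notes record a number 18 percentage points lower from compound 2 to compound 4 (beyond the scatter) and a number 10.9 percentage points lower from compound 3 to compound 4 (beyond the scatter) as well as a number 10.6 percentage points lower from compound 1 to compound 4 (beyond the scatter) for this single exchange. Compound 4 is therefore the lowest of the four, so this place does respond to the group it carries, which the steps among hydroxy, amino and pyrrolidin-1-yl could not show. A ring on the carbonyl carbon is not enough to give this outcome, as pyrrolidin-1-yl in compound 3 stays within the scatter of amino in compound 2, and no measured property or other data accompany these numbers to explain the result.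

Morpholin-4-yl and pyrrolidin-1-yl differ in more than one respect, so it remains open whether the ring oxygen or the larger ring goes with the lower number, a question that piperidin-1-yl on the same carbonyl carbon would address. Also open, as far as these compounds go, is how a dimethylamino group in this place, or a longer chain between the core and the carbonyl, would read out.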